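A Fluoro-for-Methyl Swap Among Three Inactive Analogs

This account rests on a few compounds, and the source may have more. Where it says the series, first, only, none or still open, it means among the compounds named here.

Measured compounds:
compound 1, `O=C1COc2ccc(-c3cccc(NS(=O)(=O)c4ccc(F)cc4)c3)cc2N1C1CC1`
compound 2, `Cc1ccc(N2C(=O)COc3ccc(-c4cnc5ccccc5c4)cc32)cc1`
compound 3, `O=C1COc2ccc(-c3cnc(Cl)c(NS(=O)(=O)c4ccc(F)cc4)c3)cc2N1`

In a functional assay on A549 cells (Homo sapiens) for antiproliferative activity, read by MTT assay, with a stated time of 72 h (a lower number here means a stronger inhibitor, a higher number a weaker inhibitor), compound 1 gives only a limit, > 40000 nM. Compound 2 likewise reaches only a limit in this assay, > 40000 nM. Compound 3 also returns only a limit, > 40000 nM. Within the data shown here, compound 2 thus stands nowhere apart from the others: all three rest at the limit of > 40000 nM in this assay, at which 3 of the 3 values shown sit, and no step between them can be sized. Compound 4, `O=C1COc2ccc(-c3cnc4ccccc4c3)cc2N1c1ccc(F)cc1`, is not yet measured; it differs from compound 2 by fluoro in place of methyl on an aromatic carbon. With every shown value a limit, the step in this assay is expected to be none beyond the scatter, and the estimated step is a step that the limit leaves unreadable from compound 2 to compound 4. Compound 4 is therefore expected to give about 60000 nM, within 20000 nM to 200000 nM, most likely reported again as a limit.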

Compound 4, half-maximal inhibitory concentration: > 40000 nM
Compound 4 ended at the assay's limit (the forecaster's own chance of this, stated with the estimate: 85%); the middle value does not contradict the limit.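

No step can be read from compound 2 to compound 4 in this assay: both values are limits. The compounds shown leave open what change, if any, would bring a measurable value in this assay.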